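The source may report more compounds than this note shows. Statements on the series, on what has been measured and on what is new or still open speak of the compounds shown alone.

Measured compounds, all in an ADME assay on HepG2 cells (Homo sapiens) for cytotoxicity, read by MTT assay, with a stated time of 72 h; a higher number here means that more compound is tolerated, a lower number that less compound is tolerated:
- compound 1 `CS(=O)(=O)Cc1nc2c(Br)cc(Cl)cn2c1N` gives > 125000 nM, a limit
- compound 2 `CS(=O)(=O)Cc1nc2c(Sc3ccc(Cl)cc3)cc(Cl)cn2c1[N+](=O)[O-]` gives > 31200 nM, a limit
- compound 3 `CSCc1nc2c(Br)cc(Cl)cn2c1[N+](=O)[O-]` gives > 15600 nM, a limit

Compound 2 stands at the limit of > 31200 nM in this assay, at which 1 of the 3 values shown sits. Among the measured compounds shown here, the other two compounds also have only limits, so no order among the three can be read from these results and no measured step is available.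

Compound 4 `O=[N+]([O-])c1c(CSc2ccccc2)nc2c(Sc3ccc(Cl)cc3)cc(Cl)cn12` has not yet been measured. It carries phenylsulfanyl in place of methylsulfonyl on a saturated chain carbon bound to an aromatic carbon, and the exchange is counted as phenylsulfanyl in place of methylsulfonyl on a saturated chain carbon bound to an aromatic carbon. For the measured compounds named here, no measured pair shows the size of this change, so the expectation rests on the change itself and on the reference value of compound 2, the limit > 31200 nM.

A modest move towards less tolerated compound is expected, with a real chance that the result is again only a limit. The expected change is an at least 1.5-fold lower number from compound 2 to compound 4 (0.19 log units; that floor lies within the scatter). The estimated value for compound 4 is 20000 nM, with an expected range from 6000 nM to 60000 nM.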

Compound 4, half-maximal cytotoxic concentration: > 15600 nM
Compound 4: no number, only a limit (the forecaster's own chance of this, stated with the estimate: 50%); the middle value lies beyond the limit too.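

Compound 2 and compound 4 each give only a limit in this assay, so the step between them cannot be read. The compounds shown leave open where the half-maximal cytotoxic concentration of either compound lies, and whether phenylsulfanyl in place of methylsulfonyl on a saturated chain carbon bound to an aromatic carbon changes it at all.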